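The source may hold more compounds than are shown below. What is called first, only, known or untested is meant among the compounds shown, and "the series" means these compounds.

Measured so far in a functional assay on BJAB cells (Homo sapiens) for antiproliferative activity, with a stated time of 4 days; a higher number here means that more compound is needed for the effect, a lower number that less compound is needed:
- compound 1 `COc1ccc(C)cc1-c1c(C)nn(-c2nc(-c3ccc(Cl)c(Cl)c3)c(SC(C)C)s2)c1C(=O)O` gives 9500 nM
- compound 2 `Cc1nn(-c2nc(-c3ccc(Cl)c(Cl)c3)c(SC(C)C)s2)c(C(=O)O)c1-c1cccc(Cl)c1C` gives 5100 nM
- compound 3 `Cc1ccc(-c2c(C)nn(-c3nc(-c4ccc(Cl)c(Cl)c4)c(SC(C)C)s3)c2C(=O)O)cc1` gives 3800 nM

Compound 3 has the lowest of the three numbers in this assay. Its gap to compound 2 is small: a 1.3-fold lower number from compound 2 to compound 3 (0.13 log units; within the scatter). Its gap to compound 1 is the only one beyond the scatter: a 2.5-fold lower number from compound 1 to compound 3 (0.40 log units; beyond the scatter). The step of a 1.9-fold lower number from compound 1 to compound 2 (0.27 log units; within the scatter) lies within the scatter.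

Compound 4 `COc1cc(-c2c(C)nn(-c3nc(-c4ccc(Cl)c(Cl)c4)c(SC(C)C)s3)c2C(=O)O)cc(C(F)(F)F)c1` is not yet measured. Its difference from compound 3:
3-methoxy-5-(trifluoromethyl)phenyl in place of 4-methylphenyl on an aromatic carbon

All three measured steps change the same group on the same aromatic carbon, and none of them is large; the whole spread across compounds 1, 2 and 3 is small. Going by the values given here, compound 1, the only one carrying a methoxy group on that ring, gives the highest number, and compound 4 also carries a methoxy group there, together with a trifluoromethyl group not seen in any measured compound. A modest rise in the number is therefore expected, with wide uncertainty. The estimated step is a 1.7-fold higher number from compound 3 to compound 4 (0.23 log units; within the scatter), and compound 4 is expected to give about 6500 nM in this assay, within 2500 nM to 17000 nM.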

Compound 4, half-maximal effective concentration: 1380 nM
Compound 4: the middle estimate sits 4.7-fold (0.67 log units) above what was measured; measured number outside the range, below it.
By their numbers in this assay, from the lowest: compound 4; then compounds 3, 2 and 1 (each within the scatter of the next, the first and the last beyond it).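

Working notes on the aryl group on the aromatic carbon next to the ring atom that bears a carboxy group: in this assay, the steps of a 2.8-fold lower number from compound 3 to compound 4 (0.44 log units; beyond the scatter) and a 3.7-fold lower number from compound 2 to compound 4 (0.57 log units; beyond the scatter) and a 6.9-fold lower number from compound 1 to compound 4 (0.84 log units; beyond the scatter) show that 3-methoxy-5-(trifluoromethyl)phenyl moves the number lower, beyond the scatter, against all three earlier aryl groups. A methoxy group on this ring does not by itself go with a higher number, as compound 1 and compound 4 both carry one yet stand at opposite ends of the series. Nothing at hand bears on the reason for this shift.

From the compounds shown here alone, it remains open whether the trifluoromethyl group, the methoxy group or the pair of them accounts for the lower number. Also open, going by these compounds, is how an amine or a longer alkyl chain on this ring would read in this assay.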